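Flavone oxime ethers: fluoro to methoxy on the pendant phenyl

The source may hold more compounds than are shown below. What is called first, only, known or untested is meant among the compounds shown, and "the series" means these compounds.

Compound 1 `CO/N=C(/COc1c(-c2ccccc2)oc2ccccc2c1=O)c1ccccc1` and compound 2 `CO/N=C(/COc1c(-c2ccccc2)oc2ccccc2c1=O)c1ccc(F)cc1` share the same core and differ only on the pendant phenyl ring. In a functional assay on SK-HEP1 cells (Homo sapiens) for antiproliferative activity (on this read-out higher numbers stand for weaker inhibition of growth and lower numbers for stronger inhibition of growth), compound 1 gives 7110000 nM, and compound 2 gives 13000000 nM. Compound 2 stands next to compound 1 as the only two measured points, and the step of a 1.8-fold higher number from compound 1 to compound 2 (0.26 log units; within the scatter) separates them by no more than repeated runs of the same compound would.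

Compound 3 `CO/N=C(/COc1c(-c2ccccc2)oc2ccccc2c1=O)c1ccc(OC)cc1` is the next member. Its change from compound 2 is methoxy in place of fluoro on an aromatic carbon. For the measured compounds named here, the only measured step that touches this position is a 1.8-fold higher number from compound 1 to compound 2 (0.26 log units; within the scatter), which exchanged hydrogen for fluoro there without leaving the scatter. Going by the values given here, nothing measured so far points to a larger effect for the exchange of one small group for another at this place, so the expectation for compound 3 is a step of a 1.3-fold lower number from compound 2 to compound 3 (0.11 log units; within the scatter), meaning none beyond the scatter.

Compound 3 is therefore estimated at 10000000 nM in this assay, with a range from 3000000 nM to 40000000 nM.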

Compound 3, concentration for 50% growth inhibition: 11000000 nM
Estimate against measurement, compound 3: 1.1-fold (0.04 log units) below; measured number inside the range.
By their numbers in this assay, from the lowest: compounds 1, 3 and 2 (each within the scatter of the next).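

At the aromatic carbon para to a large group, methoxy in place of fluoro gives a 1.2-fold lower number from compound 2 to compound 3 (0.07 log units; within the scatter) in this assay and methoxy in place of hydrogen gives a 1.5-fold higher number from compound 1 to compound 3 (0.19 log units; within the scatter) and so neither exchange leaves the scatter. Hydrogen, fluoro and methoxy at this place now all stand within the scatter of one another, and this holds even for methoxy, the one group of the three that is counted with a hydrogen-bond acceptor, something the earlier exchange of hydrogen for fluoro could not show. No measurement at hand speaks to the reason for this result.

Going by these compounds, what an amine, a carboxylic acid or a longer chain would do at this carbon stays open, as does whether any group here can move the number beyond the scatter. Also open is whether the same picture holds on the other carbons of the pendant phenyl, or for changes to the oxime ether and the shared core, since the three compounds shown differ at this one place only.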